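The source may report more compounds than this note shows. Statements on the series, on what has been measured and on what is new or still open speak of the compounds shown alone.

The measured compounds in an assay on HEK293 cells for positive allosteric modulation of metabotropic glutamate receptor 3 (Rattus norvegicus), read by thallium flux, with a stated time of 2.5 min; a lower number here means a smaller maximal response, a higher number a larger maximal response:

compound 1 `CCCC(=O)c1ccc(OCCCCOc2ccc(C(=O)O)cc2C)c(C)c1O`: 40.5%
compound 2 `COC(=O)c1ccc(OCCCCOc2ccc(C(=O)CC(C)C)c(O)c2C)cc1`: 22.7%
compound 3 `Cc1c(OCCCCOc2ccc(F)c(C(=O)O)c2)ccc(C(=O)CC2CCCC2)c1C`: 12.6%

Of these three, compound 1 stands highest. Compound 2 is the nearest to it, lying lower by a margin beyond the usual scatter, and compound 3 lies furthest below, again beyond the scatter. Among the compounds with values here, no pair among the measured compounds differs in a single place, so none of them isolates one structural change by itself.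

Compound 4 `CC(=O)c1ccc(OCCCCOc2ccc(C(=O)O)cc2C)c(C)c1O` has not yet been measured. It differs from compound 1 in one place: hydrogen in place of ethyl on a saturated chain carbon bound to a carbonyl carbon. Put otherwise, propylcarbonyl becomes acetyl.

Nothing measured here tracks this change alone. The expectation therefore rests on the general picture: the compounds with larger groups at the carbonyl, compound 2 and compound 3, gave lower numbers than compound 1, but they also differ elsewhere, so that cannot be read as a rule for the ketone chain. The step of a number 9.5 percentage points lower from compound 1 to compound 4 (within the scatter) is expected to be a modest fall, close to the edge of the scatter. Compound 4 is thus estimated at about 31%, with a plausible range from 14% to 48%.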

Compound 4, largest response reached (reported as percent of maximum), in percent of the reference or control that the assay uses: 25.4%
Estimate against measurement, compound 4: 5.6 percentage points above; the measured number falls inside the stated range.
By their numbers in this assay, from the lowest: compound 3; then compounds 2 and 4 (each within the scatter of the next); then compound 1.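

In this assay, hydrogen in place of ethyl on a saturated chain carbon bound to a carbonyl carbon, which turns propylcarbonyl into acetyl, gives a number 15.1 percentage points lower from compound 1 to compound 4 (beyond the scatter), a modest fall. Within the data shown here, this is the first change here that can be read alone, and it shows that the maximal response follows the length of this chain, at least across these two groups: with everything else held, the shorter acetyl keeps part of the response but not all of it. Nothing available explains this fall.

A single pair cannot tell whether a longer chain such as pentylcarbonyl would raise the response further or lower it. It also leaves open what an amine or a cyclopentyl group on this chain carbon would do with the rest of the compound unchanged.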